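Swapping the Aromatic Hydroxyl for Fluorine

This account rests on a few compounds, and the source may have more. Where it says the series, first, only, none or still open, it means among the compounds named here.

For the measured compounds named here, compound 2 `COc1ccc(/C=C(\F)C(=O)c2cc(OC)c(OC)c(OC)c2)cc1O` is the one compound with a numerical result in an ADME assay on K562 cells (Homo sapiens) for cytotoxicity, read by MTT assay, with a stated time of 5 days; a lower number here means a stronger inhibitor, a higher number a weaker inhibitor; there compound 2 gives 13.7 nM. Compound 1 `COc1ccc(/C=C(\C#N)C(=O)c2cc(OC)c(OC)c(OC)c2)cc1F` reaches only the assay limit, reported as > 10000 nM, and so yields no number. Compound 3 `COc1ccc(/C=C(\F)C(=O)c2cc(OC)c(OC)c(OC)c2)cc1F` differs from compound 2 by fluoro in place of hydroxy on an aromatic carbon. Going by the values given here, no measured pair isolates this exchange, so its size is estimated rather than read. Compound 3 is expected to fall near 40 nM, within 10 nM to 200 nM. The estimated step of a 2.9-fold higher number from compound 2 to compound 3 (0.47 log units; beyond the scatter) amounts to a modest weakening, barely beyond the usual scatter.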

Compound 3, half-maximal inhibitory concentration: 770 nM
Estimate against measurement, compound 3: 19-fold (1.28 log units) below; measured number above the stated range.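

In this assay, the hydroxy group on the aromatic carbon proves to carry much of the potency of compound 2: fluoro in its place gives a 56-fold higher number from compound 2 to compound 3 (1.75 log units; beyond the scatter). The double-bonded chain carbon matters as well, since fluoro in place of cyano gives an at least 12-fold lower number from compound 1 to compound 3 (1.11 log units; beyond the scatter). Compound 1 is reported only as a limit of the assay: the limit of > 10000 nM in this assay, at which 1 of the 3 values shown sits.

The compounds shown leave open whether an amine on that aromatic carbon would hold the potency of compound 2. They also leave open how a chlorine or a methyl on the chain carbon would compare with fluoro.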